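The source may hold more compounds than are shown below. What is called first, only, known or untested is meant among the compounds shown, and "the series" means these compounds.

Measured so far:
compound 1 `Cc1ccc(OCC(=O)NNC(=O)c2cc3ccccc3oc2=O)c(C(=O)c2ccccc2Br)c1` — 9000 nM
compound 2 `Cc1ccc(OCC(=O)NNC(=O)c2cc3ccccc3oc2=O)c(C(=O)c2ccccc2Cl)c1` — 48400 nM
compound 3 `Cc1ccc(OCC(=O)NNC(=O)c2cc3ccccc3oc2=O)c(C(=O)c2ccc(Cl)cc2)c1` — 57800 nM

Compound 3 gives the highest number of the three in a functional assay on Ehrlich cells (Mus musculus) for cytotoxicity, read by trypan blue exclusion, with a stated time of 48 h; a lower number here means a stronger inhibitor, a higher number a weaker inhibitor; its gap to compound 2 is within the scatter, while the step of a 6.4-fold higher number from compound 1 to compound 3 (0.81 log units; beyond the scatter) lies beyond it. Compound 4 `Cc1ccc(OCC(=O)NNC(=O)c2cc3ccccc3oc2=O)c(C(=O)c2ccc(F)cc2)c1` differs from compound 3 by fluoro in place of chloro on an aromatic carbon, placed para to a large group. Within the data shown here, the steps that bear on this are the halogen exchanges: a 5.4-fold higher number from compound 1 to compound 2 (0.73 log units; beyond the scatter), a modest loss, and a 1.2-fold higher number from compound 2 to compound 3 (0.08 log units; within the scatter), within the scatter. Swapping one halogen for another has thus given at most a modest shift, sometimes none. For compound 4 a small weakening or no shift beyond the scatter is expected, a 1.3-fold higher number from compound 3 to compound 4 (0.11 log units; within the scatter). The estimate for compound 4 is 75000 nM, with a range from 25000 nM to 220000 nM.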

Compound 4, half-maximal inhibitory concentration: 43400 nM
For compound 4 the middle estimate is 1.7-fold (0.24 log units) above the measured one; low and high end bracket the measured number.
By their numbers in this assay, from the lowest: compound 1; then compounds 4, 2 and 3 (each within the scatter of the next).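

In this assay, fluoro in place of chloro on an aromatic carbon, para to a large group, gives no shift beyond the scatter (a 1.3-fold lower number from compound 3 to compound 4 (0.12 log units; within the scatter)). The 4-fluorophenyl group also stays within the scatter of the 2-chlorophenyl group (a 1.1-fold lower number from compound 2 to compound 4 (0.05 log units; within the scatter)), whereas the 2-bromophenyl group remains apart (a 4.8-fold higher number from compound 1 to compound 4 (0.68 log units; beyond the scatter)), leaving compound 1 alone as the strongest of the four. No evidence on the cause of these results is available.

Still open, from the compounds shown here alone, is whether 4-bromophenyl would match the number of compound 1. Going by these compounds, how an amine or methoxy group would read on the same ring also remains open.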